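A few compounds are considered here, and "the series" means these few. Any claim that something is new, unique, unknown or untested is made for them only; others in the source may bear on it.

Working notes on the series, following the step to compound 4. The three measured compounds, compound 1 (`COc1ccc(-c2nc(CN(C)C)sc2-c2ccc(OC)cc2)cc1`), compound 2 (`CCN(CC)C(=O)c1nc(-c2ccc(OC)cc2)c(-c2ccc(OC)cc2)s1`) and compound 3 (`COc1ccc(-c2nc(C(=O)N=C(N)N)sc2-c2ccc(OC)cc2)cc1`), differ only in the group on one aromatic carbon of the shared core. In a functional assay with Oryctolagus cuniculus as the target (on this read-out lower numbers stand for stronger inhibition and higher numbers for weaker inhibition), compound 1 gives 96 nM as a number. Compound 2 is reported only as a limit (< 10 nM) in this assay. Compound 3 is likewise reported only as a limit (> 100 nM) in this assay. It therefore sits at the weak end of the numbers shown, with an at least 10-fold higher number from compound 2 to compound 3 (1.00 log units; beyond the scatter) as the clear gap, while an at least 1.0-fold higher number from compound 1 to compound 3 (0.01 log units; that floor lies within the scatter) gives no order.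

The next change leads to compound 4 (`CCOC(=O)/C(C#N)=C/c1nc(-c2ccc(OC)cc2)c(-c2ccc(OC)cc2)s1`): a group of 9 heavy atoms (6 carbon, 1 nitrogen, 2 oxygen; no ring) in place of a group of 6 heavy atoms (2 carbon, 3 nitrogen, 1 oxygen; no ring), on an aromatic carbon, with 2-cyano-2-(ethoxycarbonyl)ethenyl entering on the aromatic carbon next to the ring nitrogen and next to the ring sulfur. Within the data shown here, no measured step involves this group. The nearest guide is the sensitivity of this carbon, seen in an at least 9.6-fold lower number from compound 1 to compound 2 (0.98 log units; beyond the scatter) and in the gap to compound 3 already noted. A modest move towards lower numbers is expected, with wide uncertainty. The expected step is an at least 3.3-fold lower number from compound 3 to compound 4 (0.52 log units; beyond the scatter) in this assay, an estimate measured from a limit. For compound 4 the estimated value is 30 nM, with an expected range from 5 nM to 200 nM in this read-out.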

Compound 4, half-maximal inhibitory concentration: < 10 nM
Compound 4 was reported as a limit (the forecaster's own chance of this, stated with the estimate: 45%); middle value at least 3.0-fold (0.47 log units) from the limit.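

In this assay compound 4 gives < 10 nM, which is a limit and not a number. On the aromatic carbon next to the ring nitrogen and next to the ring sulfur, the 2-cyano-2-(ethoxycarbonyl)ethenyl group also gives a clear move towards lower numbers, an at least 10-fold lower number from compound 3 to compound 4 (1.00 log units; beyond the scatter) and an at least 9.6-fold lower number from compound 1 to compound 4 (0.98 log units; beyond the scatter), so diethylcarbamoyl is no longer the only group shown to do this, and the change brings in a group with no amide nitrogen and no hydrogen-bond donors. The step between compound 2 and compound 4 cannot be read, because both values are limits: the limit of < 10 nM in this assay, at which 2 of the 4 values shown sit.

From the compounds shown here alone, how far compound 2 and compound 4 lie beyond that limit, and whether either of them differs from the other, stays open. Also open, going by these compounds, is which part of the new group carries the step, and whether an ethenyl bearing only a nitrile, or a carboxylic acid on this carbon, would reach equally low numbers.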